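Adding a Methyl to the Core of Compound 2

The source may hold more compounds than are shown below. What is called first, only, known or untested is meant among the compounds shown, and "the series" means these compounds.

Measured compounds:
compound 1, `Cc1cc(C)c2c(O)cc(-c3cccc4ccccc34)nc2n1`, with 372 nM in a functional assay on U-251 cells (Homo sapiens) for antiproliferative activity; on this read-out higher numbers stand for weaker inhibition of growth and lower numbers for stronger inhibition of growth
compound 2, `Cc1ccc2c(O)cc(-c3cccc(Cl)c3)nc2n1`, with 64.6 nM

Of the compounds shown here, two have been measured in this assay. Compound 2 gives the lowest of the two numbers; compound 1 gives a higher number, and the gap between them lies beyond the usual scatter. The two compounds differ in more than one place, so their values are simply noted side by side and no single cause is drawn from them.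

Compound 3, `Cc1cc(C)c2c(O)cc(-c3cccc(Cl)c3)nc2n1`, is not yet measured. It differs from compound 2 in one place: methyl in place of hydrogen on an aromatic carbon.

For the measured compounds named here, no pair of measured compounds that differ only in this way is available, so the effect of this change is unknown here. A small step from compound 2 to compound 3 is expected, a 1.2-fold higher number from compound 2 to compound 3 (0.09 log units; within the scatter), most likely within the scatter and in no clear direction. Compound 3 is therefore estimated at 80 nM, with a likely range from 30 nM to 250 nM.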

Compound 3, concentration for 50% growth inhibition: 295 nM
Beside the measured number, compound 3's estimate is 3.7-fold (0.57 log units) below it; measured number outside the range, above it.
By their numbers in this assay, from the lowest: compound 2; then compounds 3 and 1 (each within the scatter of the next).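

For the compounds shown here, this is the first comparison in which only one place changes: methyl in place of hydrogen on the aromatic carbon opposite the ring nitrogen gives a 4.6-fold higher number from compound 2 to compound 3 (0.66 log units; beyond the scatter) in this assay. Since a higher number here means weaker inhibition of growth, even this one added carbon at this position costs activity when the rest of compound 2 stays the same. Nothing available explains why the added methyl has this effect.

From the compounds shown here alone, whether a different group on this carbon, such as fluorine, methoxy or an amine, would bring a similar loss remains open. Compound 1 also carries this methyl but differs from compound 3 elsewhere as well, so it cannot show whether the same change would cost activity in a different molecule.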